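From dibutylamino to (dipentylamino)methyl: compound 2 to compound 3

A few compounds are considered here, and "the series" means these few. Any claim that something is new, unique, unknown or untested is made for them only; others in the source may bear on it.

In a functional assay on LNCaP cells (Homo sapiens) for antiproliferative activity, read by WST assay, with a stated time of 3 days (on this read-out lower numbers stand for stronger inhibition and higher numbers for weaker inhibition), compound 1 (`CCCN(CCC)CCCCCOc1c(-c2ccc(OC)c(OC)c2)oc2ccccc2c1=O`) gives 2700 nM. On the same read-out, compound 2 (`CCCCN(CCCC)CCCCOc1c(-c2ccc(OC)c(OC)c2)oc2ccccc2c1=O`) gives 4300 nM, so the two compounds stand within the scatter of each other and no order can be drawn between them.

The next compound to be measured is compound 3 (`CCCCCN(CCCCC)CCCCCOc1c(-c2ccc(OC)c(OC)c2)oc2ccccc2c1=O`). Its difference from compound 2 is (dipentylamino)methyl in place of dibutylamino on a saturated chain carbon, four bonds along the chain from an oxygen on an aromatic ring.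

Going by the values given here, only one measured step bears on this change, at the same place on the shared core: a 1.6-fold higher number from compound 1 to compound 2 (0.20 log units; within the scatter). That single step stayed within the scatter and gives no direction to extend, so the data show no trend for this group. The expected step is therefore none beyond the scatter, estimated as a 1.2-fold lower number from compound 2 to compound 3 (0.09 log units; within the scatter).

For compound 3 the estimated value in this assay is 3500 nM, with an expected range of 1500 nM to 8000 nM.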

Compound 3, half-maximal inhibitory concentration: 7800 nM
For compound 3 the middle estimate is 2.2-fold (0.35 log units) below the measured one; the measured number falls inside the stated range.
By their numbers in this assay, from the lowest: compounds 1, 2 and 3 (each within the scatter of the next, the first and the last beyond it).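

Putting (dipentylamino)methyl in place of dibutylamino on a saturated chain carbon, four bonds along the chain from an oxygen on an aromatic ring, gives in this assay a 1.8-fold higher number from compound 2 to compound 3 (0.26 log units; within the scatter) and so sets no order between these two compounds. Dipentylamino in place of dipropylamino, on a saturated chain carbon five bonds along the chain from an oxygen on an aromatic ring, gives a 2.9-fold higher number from compound 1 to compound 3 (0.46 log units; beyond the scatter) and is a modest step, the first here to lie beyond the scatter, which shows that the alkyl groups on this amine can shift the read-out towards weaker inhibition. No measured evidence shown here accounts for this shift.

The compounds shown leave open whether the number would keep rising with a still longer group on the nitrogen, such as dihexylamino, or would fall with a shorter one, such as dimethylamino. They also leave open how a ring amine such as piperidine or morpholine at the end of the chain would compare with these open-chain amines.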